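Amino Replaces Fluoro: Expectation for Compound 4

A few compounds are considered here, and "the series" means these few. Any claim that something is new, unique, unknown or untested is made for them only; others in the source may bear on it.

Compound 1, `COc1ccc(CNc2cc(OC)c(OC)c(OC)c2)cc1Cl`, gives 47800 nM in a functional assay on KYSE-450 cells (Homo sapiens) for inhibition, read by MTT assay, with a stated time of 48 h; a higher number here means a weaker inhibitor, a lower number a stronger inhibitor. Compound 2, `COc1ccc(CNc2cc(OC)c(OC)c(OC)c2)cc1Br`, gives 39800 nM. Compound 3, `COc1ccc(CNc2cc(OC)c(OC)c(OC)c2)cc1F`, gives 46200 nM.

Compound 3 stands second highest of the three numbers, with a 1.0-fold lower number from compound 1 to compound 3 (0.01 log units; within the scatter) and a 1.2-fold higher number from compound 2 to compound 3 (0.06 log units; within the scatter). Compound 4, `COc1ccc(CNc2cc(OC)c(OC)c(OC)c2)cc1N`, is not yet measured. The change is amino in place of fluoro on an aromatic carbon. Within the data shown here, no measured step swaps a halogen for an amino group; the measured steps, a 1.2-fold lower number from compound 1 to compound 2 (0.08 log units; within the scatter), a 1.0-fold lower number from compound 1 to compound 3 (0.01 log units; within the scatter) and a 1.2-fold higher number from compound 2 to compound 3 (0.06 log units; within the scatter), only exchange one halogen for another, and all stay within the scatter. They therefore give no direction for this change, so the expected step is a 1.0-fold lower number from compound 3 to compound 4 (0.01 log units; within the scatter), with wide uncertainty. Compound 4 is estimated at 45000 nM, expected between 15000 nM and 135000 nM.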

Compound 4, half-maximal inhibitory concentration: 2210 nM
Beside the measured number, compound 4's estimate is 20-fold (1.31 log units) above it; the measured number lies below the stated range.
By their numbers in this assay, from the lowest: compound 4; then compounds 2, 3 and 1 (each within the scatter of the next).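

In this assay amino gives a 21-fold lower number from compound 3 to compound 4 (1.32 log units; beyond the scatter) and an 18-fold lower number from compound 2 to compound 4 (1.26 log units; beyond the scatter) and a 22-fold lower number from compound 1 to compound 4 (1.34 log units; beyond the scatter) even though the three halogens stay within the scatter of one another. This position therefore does respond to what sits on it, which exchanging one halogen for another did not reveal. No measurement given here explains why the number falls.

Still open, on these data alone, is whether a hydroxyl, a methylamino or a dimethylamino group, or an acetamide, in this place would keep the low number. That would show how specific the gain is to the plain amino group.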